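Swapping methyl for bromo on a chalcone-like quinoxaline dioxide

The source may report more compounds than this note shows. Statements on the series, on what has been measured and on what is new or still open speak of the compounds shown alone.

Compound 1 `Cc1c(C(=O)/C=C/c2ccc(Cl)cc2)[n+]([O-])c2ccccc2[n+]1[O-]` gives 19000 nM in a functional assay on HSC-4 cells (Homo sapiens) for cytotoxicity, with a stated time of 48 h; a higher number here means that more compound is tolerated, a lower number that less compound is tolerated.
Compound 2 `Cc1c(C(=O)/C=C/c2ccc(Cl)c(Cl)c2)[n+]([O-])c2ccccc2[n+]1[O-]` gives 15000 nM in this assay.
Compound 3 `Cc1ccc(/C=C/C(=O)c2c(C)[n+]([O-])c3ccccc3[n+]2[O-])cc1` gives 11000 nM in this assay.

All three compounds share the same core and differ only in the groups on the phenyl ring at the end of the double-bonded chain. Compound 3 sits at the end of the measured range, but its distances from the others, a 1.7-fold lower number from compound 1 to compound 3 (0.24 log units; within the scatter) and a 1.4-fold lower number from compound 2 to compound 3 (0.13 log units; within the scatter), are within the scatter, so the three cannot be told apart on these numbers. The same holds for a 1.3-fold lower number from compound 1 to compound 2 (0.10 log units; within the scatter).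

Compound 4 `Cc1c(C(=O)/C=C/c2ccc(Br)cc2)[n+]([O-])c2ccccc2[n+]1[O-]` is not yet measured. It differs from compound 3 by bromo in place of methyl on an aromatic carbon. The step that bears most on this is the reverse of the change from compound 1 to compound 3, where methyl replaced chloro: a 1.7-fold lower number from compound 1 to compound 3 (0.24 log units; within the scatter). Exchanging one halogen for another on that ring, as in a 1.3-fold lower number from compound 1 to compound 2 (0.10 log units; within the scatter), also moved the number little. Compound 4 is therefore expected to land close to compound 3, with a step of a 1.4-fold higher number from compound 3 to compound 4 (0.13 log units; within the scatter), inside the scatter. The estimate for compound 4 is 15000 nM, with a range from 7000 nM to 32000 nM.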

Compound 4, half-maximal cytotoxic concentration: 36000 nM
Compound 4: the middle estimate sits 2.4-fold (0.38 log units) below what was measured; the measured number lies above the stated range.
By their numbers in this assay, from the lowest: compounds 3, 2, 1 and 4 (each within the scatter of the next, the first and the last beyond it).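

In this assay, for the compounds shown here, the groups on this ring produce a step beyond the scatter for the first time (a 3.3-fold higher number from compound 3 to compound 4 (0.51 log units; beyond the scatter)), so 4-bromophenyl and 4-methylphenyl can be told apart, with more compound tolerated for the bromo compound. The change from 3,4-dichlorophenyl to 4-bromophenyl also goes beyond the scatter (a 2.4-fold higher number from compound 2 to compound 4 (0.38 log units; beyond the scatter)), whereas bromo in place of chloro stays within it (a 1.9-fold higher number from compound 1 to compound 4 (0.28 log units; within the scatter)), so these two halogens cannot be separated on this ring. Nothing available here explains why bromo and methyl differ.

As far as these compounds go, it remains open how a different group at this place, such as an amine, a methoxy group or a carboxylic acid, would compare with bromo. From the compounds shown here alone, it is also open whether the step from methyl to bromo would keep its size on a different core.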